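The source may hold more compounds than are shown below. What is called first, only, known or untested is meant among the compounds shown, and "the series" means these compounds.

Measured so far:
Compound 1 `O=C1C(=O)N(Cc2ccc(-c3cncnc3)cc2)c2ccc(OC(F)(F)F)cc21`: 2100 nM in a functional assay on CHO cells for positive allosteric modulation of muscarinic acetylcholine receptor M5 (Homo sapiens), read by FLIPR and calcium flux, with a stated time of 1 h; on this read-out higher numbers stand for an effect only at larger amounts of compound and lower numbers for an effect already at smaller amounts
Compound 2 `O=C1C(=O)N(Cc2ccc(-c3cccnc3)cn2)c2ccc(OC(F)(F)F)cc21`: > 30000 nM in this assay, a limit of the assay rather than a number

Compound 1 is thus the only one of the two that gives a number in this assay. Among the measured compounds shown here, for compound 2 the result sits at the limit of > 30000 nM in this assay, at which 1 of the 2 values shown sits, which is a limit and not a measured value, so no measured step between the two can be stated.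

Compound 3, `O=C1C(=O)N(Cc2ccc(-c3ccccc3)cc2)c2ccc(OC(F)(F)F)cc21`, differs from compound 1 in one place: phenyl in place of pyrimidin-5-yl on an aromatic carbon. For the measured compounds named here, no measured pair in this set shows this same change, so the size of the step is open. Both groups are six-membered aromatic rings on the same aromatic carbon, and the expectation is a modest step in this assay, tending toward an effect only at somewhat larger amounts of compound 3, yet one that may well stay within the usual scatter. Compound 3 is therefore expected to come out near 3000 nM, with a likely range from 800 nM to 12000 nM. The step of a 1.4-fold higher number from compound 1 to compound 3 (0.15 log units; within the scatter) is the expected outcome of this change.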

Compound 3, half-maximal effective concentration: 1600 nM
Beside the measured number, compound 3's estimate is 1.9-fold (0.27 log units) above it, within the range that was stated.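

Among the compounds shown here, for the first time a change at this place can be read as a measured step, since phenyl in place of pyrimidin-5-yl gives a 1.3-fold lower number from compound 1 to compound 3 (0.12 log units; within the scatter) in this assay and so leaves the two compounds indistinguishable on this read-out. The position in question is an aromatic carbon of a six-membered aromatic ring of carbon only, para to a large group, and here a ring of carbon only serves as well as the ring with two hetero atoms. The hetero atoms and hydrogen-bond acceptors of pyrimidin-5-yl are therefore not required for a measured number in this assay in this pair, although a single pair cannot show whether that holds for other rings or other cores.

On these data alone, whether a non-aromatic ring such as morpholine, an amine, a carboxylic acid or a small group such as methyl would be tolerated at this same place remains open, as does the effect of a substituent such as fluorine on the phenyl ring of compound 3. The compounds shown offer no measured property that would explain why these two rings give results so alike.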